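Removing one chloro from a dichloropurine benzyl series

The source may report more compounds than this note shows. Statements on the series, on what has been measured and on what is new or still open speak of the compounds shown alone.

Measured compounds:
- compound 1, `ClCc1ccccc1Cn1cnc2c(Cl)ncnc21`: 3020 nM
- compound 2, `ClCc1ccc(Cn2cnc3nc(Cl)nc(Cl)c32)cc1`: 1620 nM
- compound 3, `ClCc1ccccc1Cn1cnc2nc(Cl)nc(Cl)c21`: 16600 nM

In a functional assay on MDA-MB-435 cells (Homo sapiens) for cytotoxicity, read by sulforhodamine B assay, with a stated time of 48 h (on this read-out lower numbers stand for stronger inhibition of growth and higher numbers for weaker inhibition of growth), compound 2 gives 1620 nM. This is the lowest of the three numbers, but compound 1 sits within the scatter of it, so no order between those two can be claimed; compound 3 stands well beyond the scatter on the weaker side.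

The unmeasured compound 4, `ClCc1ccc(Cn2cnc3ncnc(Cl)c32)cc1`, differs from compound 2 in one place: hydrogen in place of chloro on an aromatic carbon. The ring and the chloromethylbenzyl group are otherwise unchanged.

Going by the values given here, no measured pair covers exactly this change. What the data do show is that compound 1, which carries a single chloro on the shared core, gives 3020 nM, whereas compound 3, which carries two chloro groups on the same core with the same ortho-substituted benzyl, gives 16600 nM. Those two values lie far apart, with the single-chloro compound on the stronger side.

On that basis compound 4 is expected to give a lower number than compound 2, with an estimated step from compound 2 to compound 4 of a 2.3-fold lower number from compound 2 to compound 4 (0.36 log units; beyond the scatter) in this assay. Compound 4 is estimated at 700 nM, with a range from 200 nM to 2500 nM.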

Compound 4, concentration for 50% growth inhibition: 5880 nM
Compound 4: the middle estimate sits 8.4-fold (0.92 log units) below what was measured; measured number outside the range, above it.
By their numbers in this assay, from the lowest: compounds 2, 1 and 4 (each within the scatter of the next, the first and the last beyond it); then compound 3.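

In this assay, the change from chloro to hydrogen on the aromatic carbon between two ring nitrogen atoms gives a 3.6-fold higher number from compound 2 to compound 4 (0.56 log units; beyond the scatter), a modest step toward weaker inhibition of growth. This is the first pair among these compounds to isolate that position, with the remaining chloro and the chloromethylbenzyl group unchanged, and it shows that the chloro at this carbon goes with the lower number on the scaffold of compound 2. Nothing given here explains why the number rises when this chloro leaves.

The compounds shown leave open how an amine, a methoxy group or a methylthio group would read at this carbon, as only chloro and hydrogen appear there on this scaffold. They also leave open whether the same replacement would give a step of similar size and direction with the benzyl arrangement of compound 3, and whether the result would hold with a hydroxymethyl group in place of the chloromethyl group on the benzyl ring.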